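A few compounds are considered here, and "the series" means these few. Any claim that something is new, unique, unknown or untested is made for them only; others in the source may bear on it.

Compound 1 `COc1cc(-c2cc(/C=C/C(=O)c3ccc(Cl)c(Cl)c3)[nH]n2)cc(OC)c1OC` and compound 2 `COc1ccc(C(=O)/C=C/c2cc(-c3cc(OC)c(OC)c(OC)c3)n[nH]2)cc1OC` share one core and differ only in the ring attached to the carbonyl carbon. In a functional assay on ACHN cells (Homo sapiens) for cytotoxicity, read by sulforhodamine B assay, with a stated time of 48 h, tested at 1 uM (a higher number here means a weaker effect of the compound at the concentration tested, a lower number a stronger effect), compound 1 gives 101%, and compound 2 gives 91%. The step of a number 10 percentage points lower from compound 1 to compound 2 (within the scatter) is within the scatter, so both compounds show only a weak effect at the concentration tested, and compound 2 cannot be told apart from compound 1 on these numbers.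

Compound 3 `COc1ccc(C(=O)/C=C/c2cc(-c3cc(OC)c(OC)c(OC)c3)n[nH]2)cc1` is the next step: hydrogen in place of methoxy on an aromatic carbon. Among the measured compounds shown here, no measured step touches this part of the molecule. For the measured compounds named here, the only guide is that exchanging the whole ring on the carbonyl carbon, from compound 1 to compound 2, stayed within the scatter. For compound 3 the step in this assay is therefore expected to stay within the scatter as well, at a number 2 percentage points higher from compound 2 to compound 3 (within the scatter). Compound 3 is estimated at 93%, with a range from 80% to 105%.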

Compound 3, a percentage reported as activity, at one concentration (the size of the read-out at that concentration, not a potency): 105%
Estimate against measurement, compound 3: 12 percentage points below; low and high end bracket the measured number.
By their numbers in this assay, from the lowest: compounds 2, 1 and 3 (each within the scatter of the next, the first and the last beyond it).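

Taking the methoxy off the 3,4-dimethoxyphenyl ring to leave 4-methoxyphenyl gives, in this assay, a number 14 percentage points higher from compound 2 to compound 3 (beyond the scatter) and is the first step here to pass the scatter, though only modestly. The second methoxy on this ring therefore goes with a slightly stronger effect, while the comparison with the dichloro ring gives a number 4 percentage points higher from compound 1 to compound 3 (within the scatter) and does not separate those two rings. Nothing available explains the difference between compound 2 and compound 3. From the compounds shown here alone, it remains open whether a hydroxyl, an amine or a longer chain such as ethoxy at this position, ortho to the remaining methoxy group, would strengthen the effect further. Going by these compounds, it also remains open whether changes on the shared core would matter more than changes on this ring.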